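A few compounds are considered here, and "the series" means these few. Any claim that something is new, unique, unknown or untested is made for them only; others in the source may bear on it.

Measured compounds:
compound 1 `COc1cc(C2=C(c3cc(C)c(OC)c(C)c3)C(O)CC2=O)cc(OC)c1OC` — in an ADME assay on ECV-304 cells (Homo sapiens) for cytotoxicity, read by MTT assay, with a stated time of 72 h (on this read-out higher numbers stand for weaker inhibition and lower numbers for stronger inhibition), compound 1 gives > 100 ug/mL, which is a limit of the assay.
compound 2 `COc1ccc(C2=C(c3cc(OC)c(OC)c(OC)c3)C(=O)C(OC(C)=O)C2)cc1O` — in this assay compound 2 gives > 100 ug/mL, again a limit.
compound 3 `COc1ccc(C2=C(c3cc(OC)c(OC)c(OC)c3)CC(O)C2=O)cc1N` — in this assay compound 3 gives > 100 ug/mL, again a limit.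

Compound 1 therefore has no numeric value in this assay; it stands at the limit of > 100 ug/mL in this assay, at which 3 of the 3 values shown sit, together with compound 2 and compound 3. Among the measured compounds shown here, no two measured compounds differ in a single place, so no measured step exists, and no compound can be ranked against another: all three show the same limit and nothing more.

Compound 4 `COc1cc(C2=C(c3cc(C)c(OC)c(C)c3)C(OC(C)=O)CC2=O)cc(OC)c1OC` is the next member to be measured in this assay. It differs from compound 1 by acetyl in place of hydrogen on an oxygen on a saturated carbon. For the measured compounds named here, compound 2 carries the same acetoxy motif on its own core and also sits at the limit, but no step joins it to compound 1 or to compound 4, so its value only shows that an acetoxy-bearing member of the set did not fall below the limit.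

With every measured value at the limit, no change beyond the scatter is expected; the step from compound 1 to compound 4 in this assay is estimated as a step that the limit leaves unreadable from compound 1 to compound 4. Compound 4 is therefore expected to give about 150 ug/mL in this assay, within 60 ug/mL to 400 ug/mL, most likely reported again as a limit.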

Compound 4, half-maximal inhibitory concentration: > 100 ug/mL
Compound 4: a limit, no number; the forecaster's own chance of this, stated with the estimate: 85%; the middle value does not contradict the limit.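

In this assay compound 4 gives > 100 ug/mL, which is a limit and not a number. Compound 1 also carries a limit, so no step between compound 1 and compound 4 can be read: the limit of > 100 ug/mL in this assay, at which 4 of the 4 values shown sit.

The compounds shown leave open whether hydroxy to acetoxy changes the value in this assay at all, and how any compound ranks against another.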